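The source may hold more compounds than are shown below. What is called first, only, known or untested is meant among the compounds shown, and "the series" means these compounds.

Compound 2, `Cc1cc(-n2ccc3ccccc32)c2ncc(CSCCc3ccccc3)n2c1`, is one of two analogues that share a core and differ only in the aromatic group attached to it. In an ADME assay on HEL cells (Homo sapiens) for cytotoxicity, with a stated time of 3 days (a higher number here means that more compound is tolerated, a lower number that less compound is tolerated), compound 2 gives 100 ug/mL. Its companion, compound 1, `Cc1cc(-c2ccco2)c2ncc(CSCCc3ccccc3)n2c1`, carries a furan-2-yl group in that position and gives 100 ug/mL in this assay, so compound 2 stands level with compound 1 at the digits shown, and the step of no change at the digits printed from compound 1 to compound 2 (within the scatter) lies within the scatter.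

The next compound, compound 3, `Cc1cc(Sc2ccc(Cl)cc2)c2ncc(CSCCc3ccccc3)n2c1`, has not yet been measured. It differs from compound 2 by (4-chlorophenyl)sulfanyl in place of 1H-indol-1-yl on an aromatic carbon.

Within the data shown here, only one measured step bears on this change: replacing one aromatic group with another in the same place, from compound 1 to compound 2, gave no change at the digits printed from compound 1 to compound 2 (within the scatter). Among the measured compounds shown here, that is the sole guide, and it shows no movement beyond the scatter. The expectation is therefore that the swap to (4-chlorophenyl)sulfanyl will also leave the reading where it is, with an estimated step of no change at the digits printed from compound 2 to compound 3 (within the scatter). Compound 3 is estimated at 100 ug/mL, with a likely range from 40 ug/mL to 100 ug/mL.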

Compound 3, minimum cytotoxic concentration: 4 ug/mL
Estimate against measurement, compound 3: 25-fold (1.40 log units) above, outside the stated range (below it).
By their numbers in this assay, from the lowest: compound 3; then compounds 1 and 2 (each within the scatter of the next).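

In this assay, the aromatic carbon carrying these groups is not indifferent to what sits there, as (4-chlorophenyl)sulfanyl gives a 25-fold lower number from compound 2 to compound 3 (1.40 log units; beyond the scatter) and, measured against the furan-2-yl group, a 25-fold lower number from compound 1 to compound 3 (1.40 log units; beyond the scatter). The earlier pair alone showed only that furan-2-yl and 1H-indol-1-yl read alike, which could have suggested that the group at this place hardly matters; compound 3 shows that, with the rest of the molecule unchanged, one replacement at this place can leave far less compound tolerated. Nothing available here explains why this group behaves differently from the other two.

The entering group differs from both earlier groups in more than one way, since it brings both a sulfur link and a chlorine, and these compounds cannot show which of them goes with the lower number. As far as these compounds go, a phenylsulfanyl group without the chlorine, or a 4-chlorophenyl group joined directly to the aromatic carbon, would separate the two features, and whether the link or the chlorine matters more remains open.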